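From pyridin-3-yl to 1H-indol-2-yl on a shared core

This account rests on a few compounds, and the source may have more. Where it says the series, first, only, none or still open, it means among the compounds named here.

Measured so far in an ADME assay on L6 cells (Rattus norvegicus) for cytotoxicity (on this read-out higher numbers stand for weaker inhibition and lower numbers for stronger inhibition), as the read-out:
- compound 1 `O=C(Nc1c(O)cccc1-c1nc2c(C(=O)O)cccc2o1)c1ccccc1O` gives 85100 nM
- compound 2 `O=C(Nc1c(O)cccc1-c1nc2c(C(=O)O)cccc2o1)c1cccnc1` gives 240000 nM

Of these two, compound 2 holds the higher number (240000 nM) and so the weaker inhibition in this assay, and its gap to compound 1 lies beyond the scatter. The next compound, compound 3 `O=C(Nc1c(O)cccc1-c1nc2c(C(=O)O)cccc2o1)c1cc2ccccc2[nH]1`, keeps the shared core and differs from compound 2 only on a carbonyl carbon whose other neighbours are amide-type nitrogen (1H-indol-2-yl in place of pyridin-3-yl on a carbonyl carbon), with 1H-indol-2-yl in place of pyridin-3-yl. Among the measured compounds shown here, one measured step bears on this place (a 2.8-fold higher number from compound 1 to compound 2 (0.45 log units; beyond the scatter)), and it was modest. For the measured compounds named here, it shows that this group can move the number, but no measured compound carries 1H-indol-2-yl, so the evidence is indirect. Compound 2 stands at the top of the two numbers, and compound 1 gives 85100 nM with its 2-hydroxyphenyl group, so a modest fall is expected rather than a further rise. The expected change is (a 2.4-fold lower number from compound 2 to compound 3 (0.38 log units; beyond the scatter)) and its direction remains uncertain. For compound 3 the estimated value is 100000 nM with an expected range from 35000 nM to 240000 nM in this read-out.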

Compound 3, half-maximal inhibitory concentration: 212000 nM
Beside the measured number, compound 3's estimate is 2.1-fold (0.33 log units) below it, within the range that was stated.
By their numbers in this assay, from the lowest: compound 1; then compounds 3 and 2 (each within the scatter of the next).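

In this assay, the step to 1H-indol-2-yl on the carbonyl carbon is (a 1.1-fold lower number from compound 2 to compound 3 (0.05 log units; within the scatter)), so this position gives no separate reading for these two groups, even though 1H-indol-2-yl carries a hydrogen-bond donor where pyridin-3-yl carries a hydrogen-bond acceptor. The 2-hydroxyphenyl group of compound 1 now stands apart from two different groups rather than one, with (a 2.5-fold higher number from compound 1 to compound 3 (0.40 log units; beyond the scatter)) of modest size alongside the earlier (a 2.8-fold higher number from compound 1 to compound 2 (0.45 log units; beyond the scatter)), so the gap seen first is not tied to pyridin-3-yl alone. Nothing in the data shown offers an explanation for this pattern.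

The compounds shown leave open whether a plain phenyl or a 2-methoxyphenyl group on this carbonyl carbon would read with compound 1 or with compound 2 and compound 3, which would help show whether the hydroxyl of compound 1 matters here. They also leave open how a group that is not an aromatic ring, such as a short alkyl chain or an aminoalkyl chain, would read at this position.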